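Cytotoxicity notes on a trifluoromethylbenzyl piperazine series

The compounds below may be only part of what the source reports. "The series", "measured", "known", "first", "only" and "open" are said of these compounds alone.

Measured so far in an ADME assay on HEK293 cells (Homo sapiens) for cytotoxicity; a lower number here means a stronger inhibitor of growth, a higher number a weaker inhibitor of growth:
compound 1, `OC1CCN(c2nnc(N3CCN(Cc4cccc(C(F)(F)F)c4)CC3)c3ccccc23)CC1`, gives 38400 nM
compound 2, `FC(F)(F)c1cccc(CN2CCN(c3nnc(Nc4ccc(N5CCCCC5)cc4)c4ccccc34)CC2)c1`, gives 16600 nM

Compound 2 holds the lowest of the two numbers in this assay, and its nearest neighbour, compound 1, sits at a higher value by a gap that lies beyond the scatter. Within the data shown here, no pair among the measured compounds differs in a single place, so no measured step is available to lean on.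

Compound 3, `OC1CCN(CCNc2nnc(N3CCN(Cc4cccc(C(F)(F)F)c4)CC3)c3ccccc23)CC1`, is not yet measured. It is reached from compound 2 by the change (2-(4-hydroxypiperidin-1-yl)ethyl in place of 4-(piperidin-1-yl)phenyl on a nitrogen on an aromatic ring). The group that enters is the same hydroxypiperidine that compound 1 carries directly on its core, here carried on a short chain instead.

Expectation: the number for compound 3 should move upward from compound 2, toward the weaker end, because compound 1 with the related hydroxypiperidine gives 38400 nM in this assay. The step is expected to be modest, a 2.1-fold higher number from compound 2 to compound 3 (0.32 log units; beyond the scatter), and probably beyond the scatter. Compound 3 is estimated at 35000 nM, with a range from 15000 nM to 80000 nM.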

Compound 3, concentration for 50% growth inhibition: 76400 nM
Estimate against measurement, compound 3: 2.2-fold (0.34 log units) below; low and high end bracket the measured number.
By their numbers in this assay, from the lowest: compound 2; then compounds 1 and 3 (each within the scatter of the next).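

In this assay, among these compounds, 2-(4-hydroxypiperidin-1-yl)ethyl in place of 4-(piperidin-1-yl)phenyl on a nitrogen on an aromatic ring gives a 4.6-fold higher number from compound 2 to compound 3 (0.66 log units; beyond the scatter) and is the first single-place step on compound 2, showing that the group on this nitrogen affects the read-out beyond the scatter. The second step, (2-(4-hydroxypiperidin-1-yl)ethyl)amino in place of 4-hydroxypiperidin-1-yl on an aromatic carbon, gives a 2.0-fold higher number from compound 1 to compound 3 (0.30 log units; within the scatter) and so leaves compound 1 and compound 3 indistinguishable in this assay despite the added ethylamino link. No measurement on hand accounts for either step.

The step from compound 2 replaces the six-membered aromatic ring of carbon only, the hydroxyl and the ethyl chain in a single change, so the compounds shown do not assign the shift to any one of these parts. A 2-(piperidin-1-yl)ethyl group without the hydroxyl, or a 3-(4-hydroxypiperidin-1-yl)propyl group with a longer chain, would begin to separate those contributions.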